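The source may report more compounds than this note shows. Statements on the series, on what has been measured and on what is new or still open speak of the compounds shown alone.

Compound 1 `CCCCCCNC(=O)n1cc(CC)c(=O)[nH]c1=O` is the stronger of the two compounds measured in an assay on HEK293 cells for inhibition of acid ceramidase (Rattus norvegicus), read by LC-MS, with a stated time of 30 min (a lower number here means a stronger inhibitor, a higher number a weaker inhibitor), where compound 1 gives 733 nM. The other compound measured, compound 2 `CCCCCCNC(=O)n1cc(N(C)Cc2ccccc2)c(=O)[nH]c1=O`, carries a larger group on the same ring carbon and is weaker: in this assay compound 2 gives 5500 nM, a gap from compound 1 that lies beyond the scatter of the measurement. Among the compounds with values here, no direct single-point step between measured compounds is available, so the weight of this one comparison is limited.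

The compound now in question is compound 3 `CCCCCCNC(=O)n1cc(-c2ccccc2)c(=O)[nH]c1=O`. It differs from compound 1 in a single place: phenyl in place of ethyl on an aromatic carbon. Both groups are carbon only, and neither brings a donor or an acceptor, so the change is one of size and of ring versus chain rather than of polarity.

Given that the only larger group seen at this position, in compound 2 with 5500 nM, read weaker than compound 1, the step from compound 1 to compound 3 is expected to be small and, if anything, toward a weaker inhibitor, a 1.8-fold higher number from compound 1 to compound 3 (0.25 log units; within the scatter). For compound 3 the estimated value in this assay is therefore 1300 nM, with a plausible range from 300 nM to 5500 nM.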

Compound 3, half-maximal inhibitory concentration: 177 nM
Beside the measured number, compound 3's estimate is 7.3-fold (0.87 log units) above it; measured number outside the range, below it.
By their numbers in this assay, from the lowest: compound 3; then compound 1; then compound 2.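

In this assay, putting phenyl in place of ethyl on this aromatic carbon gives a 4.1-fold lower number from compound 1 to compound 3 (0.62 log units; beyond the scatter), so this position accepts a six-membered aromatic ring of carbon only and the inhibitor gains strength. Within the data shown here, until this result, the only larger group seen on this carbon was the one in compound 2, at 5500 nM, which read weaker than compound 1; compound 3 now goes against any simple rule that a larger group here means a weaker inhibitor, and what separates the two larger groups remains unexplained. Nothing measured here accounts for the gain with phenyl.

The three compounds leave open whether the gain goes with the aromatic ring itself or simply with more carbon, which a cyclohexyl group on the same carbon would help to separate, and whether a pyridyl ring or a phenyl carrying fluorine or methoxy would keep it. They also leave open whether the step would hold with a different group meta to this position, since all three compounds share the same group of 9 heavy atoms there.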